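Butyl in place of bromo at the far end of compound 3

The source may hold more compounds than are shown below. What is called first, only, known or untested is meant among the compounds shown, and "the series" means these compounds.

Compound 1, `CC(O)c1cn(Cc2cc(=O)oc3cc(O)ccc23)nn1`: in a functional assay on HeLa cells (Homo sapiens) for inhibition, read by MTT assay, with a stated time of 72 h (a lower number here means a stronger inhibitor, a higher number a weaker inhibitor), compound 1 gives > 100000 nM, which is a limit of the assay and not a number.
Compound 2, `CCCCCCc1cn(Cc2cc(=O)oc3cc(O)ccc23)nn1`: in this assay compound 2 gives 59000 nM.
Compound 3, `O=c1cc(Cn2cc(-c3ccc(Br)cc3)nn2)c2ccc(O)cc2o1`: in this assay compound 3 gives 40200 nM.

Compound 3 and compound 2 sit within the scatter of each other, as a 1.5-fold lower number from compound 2 to compound 3 (0.17 log units; within the scatter) shows, and the remaining value, that of compound 1, is only a limit. The step of an at least 2.4-fold lower number from compound 1 to compound 3 (0.39 log units; beyond the scatter) lies beyond the scatter, while an at least 1.6-fold lower number from compound 1 to compound 2 (0.22 log units; that floor lies within the scatter) does not.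

Compound 4, `CCCCc1ccc(-c2cn(Cc3cc(=O)oc4cc(O)ccc34)nn2)cc1`, has not yet been measured. It differs from compound 3 in one place: butyl in place of bromo on an aromatic carbon. For the measured compounds named here, two measured steps bear on this change. The step of an at least 1.6-fold lower number from compound 1 to compound 2 (0.22 log units; that floor lies within the scatter), where a longer chain replaced a short one, and the step of a 1.5-fold lower number from compound 2 to compound 3 (0.17 log units; within the scatter), where a chain gave way to the 4-bromophenyl group, were each within the scatter. Replacing bromo by butyl on that same ring is therefore expected to give, in this assay, a step of a 1.3-fold lower number from compound 3 to compound 4 (0.13 log units; within the scatter), that is, no change beyond the scatter. Compound 4 is expected to give about 30000 nM, within a range of 10000 nM to 90000 nM.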

Compound 4, half-maximal inhibitory concentration: 39000 nM
Estimate against measurement, compound 4: 1.3-fold (0.11 log units) below; the range from low to high includes it.
By their numbers in this assay, from the lowest: compounds 4, 3 and 2 (each within the scatter of the next). At a limit, above all of these: compound 1.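

On the six-membered aromatic ring of carbon only, at the carbon para to a large group, butyl with its 4 carbon atoms takes the place of bromo, a single heavy atom, and this assay records a 1.0-fold lower number from compound 3 to compound 4 (0.01 log units; within the scatter). The earlier steps shown here swapped the whole group on an aromatic carbon of the shared core, whereas this step alters only the far end of the 4-bromophenyl group and leaves the rest of compound 3 untouched. It shows that, at this one position, exchanging a lone bromo for a butyl chain with no hydrogen-bond donors or acceptors on either side leaves the number unchanged within the scatter, so this pair gives no sign that the read-out depends on which of these two groups is present.

Going by these compounds, whether an amine, a carboxylic acid or a longer chain such as octyl at this same carbon would move the number beyond the scatter remains open. The value of compound 1, the only compound in the set with a hydroxyl on its side group, is a limit and not a number: the limit of > 100000 nM in this assay, at which 1 of the 4 values shown sits.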